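Trimming the Ester Chain from Ethyl to Methyl

This account rests on a few compounds, and the source may have more. Where it says the series, first, only, none or still open, it means among the compounds named here.

Compound 1 `CCCCCCCCOC(=O)C(O)Cn1cnc2c(N)ncnc21` carries a long chain on its ester, while compound 2 `CCOC(=O)C(O)Cn1cnc2c(N)ncnc21` carries a short one. In a functional assay on HeLa cells (Homo sapiens) for cytotoxicity (on this read-out higher numbers stand for lower toxicity in this test and lower numbers for higher toxicity in this test), compound 1 gives 100 ug/mL. In this assay compound 2 gives > 400 ug/mL, which is a limit of the assay and not a number. Compound 2 therefore stands at the limit of > 400 ug/mL in this assay, at which 1 of the 2 values shown sits. The step of an at least 4.0-fold higher number from compound 1 to compound 2 (0.60 log units; beyond the scatter) is at least modest. Compound 3 `COC(=O)C(O)Cn1cnc2c(N)ncnc21` continues in the same direction by a single carbon: hydrogen in place of methyl on a saturated chain carbon bound to an oxygen next to a carbonyl group. Among the compounds with values here, only the step from compound 1 to compound 2 bears on this change, and it removed a much larger piece than the one lost here, so no shift of comparable size is expected. The expected step of a number no higher from compound 2 to compound 3 (the limit leaves the size open) is none beyond the scatter. Compound 3 is expected to give 400 ug/mL in this assay, with a range from 200 ug/mL to 800 ug/mL, and quite possibly again only as a limit.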

Compound 3, minimum cytotoxic concentration: > 400 ug/mL
Compound 3: only a limit was reported; the forecaster's own chance of this, stated with the estimate: 75%; the middle value lies on the limit itself.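

Compound 3 shows that the move from ethyl to methyl on the ester does not bring the number in this assay back towards that of the long-chain ester, and the gap to that compound remains: an at least 4.0-fold higher number from compound 1 to compound 3 (0.60 log units; beyond the scatter). The shorter ester therefore keeps the same reading as compound 2, with both values given only as limits of the assay. The step between these two compounds cannot be read, and the series now ends at that ceiling: the limit of > 400 ug/mL in this assay, at which 2 of the 3 values shown sit.

Going by these compounds, how much compound 2 and compound 3 differ beyond the limit stays open. Also open, on these data alone, is where between the ethyl and the long chain the number starts to drop, for example with a butyl chain, and what a carboxylic acid or an amide in place of the ester would give.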